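This account rests on a few compounds, and the source may have more. Where it says the series, first, only, none or still open, it means among the compounds named here.

Compound 1, `C=CCn1nc(Cc2ccc(Cl)cc2)c2ccccc2c1=O`: 2600 nM
Compound 2, `CSc1ccc(Cc2nn(-c3ccc(Br)cc3)c(=O)c3ccccc23)cc1`: only a limit in this assay

In a functional assay on aorta with Alpha-1D adrenergic receptor (Rattus norvegicus) as the target (a lower number here means that less compound is needed, a higher number that more compound is needed for the effect), compound 1 gives 2600 nM. Compound 2 reaches only the limit of the assay, > 100000 nM, so its place is a limit rather than a number, as the limit of > 100000 nM in this assay, at which 1 of the 2 values shown sits, shows. Compound 3, `O=c1c2ccccc2c(Cc2ccc(Cl)cc2)nn1-c1ccc(Br)cc1`, differs from compound 2 in one place: chloro in place of methylsulfanyl on an aromatic carbon. For the measured compounds named here, no measured step joins these two compounds, so the size of the change is open; a step within the scatter, or a small gain, seems most likely. Compound 3 is expected to remain weak, estimated at 60000 nM (range 8000 nM to 300000 nM), which would mean a step of an at least 1.6-fold lower number from compound 2 to compound 3 (0.22 log units; that floor lies within the scatter).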

Compound 3, half-maximal effective concentration: > 30000 nM
Compound 3 ended at the assay's limit; the forecaster's own chance of this, stated with the estimate: 50%; the middle value does not contradict the limit.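

In this assay compound 3 gives only a limit, > 30000 nM, not a number. Compound 2 stands at a limit as well, so the step from methylsulfanyl to chloro on the aromatic carbon cannot be read. The nitrogen gives the first readable step: with the 4-chlorobenzyl group kept, 4-bromophenyl in place of allyl gives an at least 11-fold higher number from compound 1 to compound 3 (1.06 log units; beyond the scatter).

From the compounds shown here alone, it remains open whether a propyl chain or a plain benzyl on that nitrogen would hold the value of compound 1. Also open, going by these compounds, is how chloro and methylsulfanyl compare with allyl on the nitrogen.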